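A few compounds are considered here, and "the series" means these few. Any claim that something is new, unique, unknown or untested is made for them only; others in the source may bear on it.

Measured in a toxicity assay on GES1 cells (Homo sapiens) for inhibition, read by MTT assay, with a stated time of 72 h; a lower number here means a stronger inhibitor, a higher number a weaker inhibitor:
Compound 1 `Cc1cc(N2CC[C@@H](C)[C@@H](N(C)c3ncnc4[nH]ccc34)C2)n2nc(SCc3csc4ccc(Cl)cc34)nc2n1`: > 100000 nM
Compound 2 `C#CSc1nc2nc(C)cc(N3CC[C@@H](C)[C@@H](N(C)c4ncnc5[nH]ccc45)C3)n2n1`: > 100000 nM

Both entries are limits of the assay, not exact numbers. Among the compounds with values here, compound 2 therefore has no exact place on the scale: it reads > 100000 nM, a limit, and the only other value is a limit too. Compound 3 `Cc1cc(N2CC[C@@H](C)[C@@H](N(C)c3ncnc4[nH]ccc34)C2)n2nc(SCCCc3ccccc3)nc2n1` carries 3-phenylpropyl in place of ethynyl on a sulfur. Within the data shown here, the one measured step on that sulfur is a step that the two limits leave unreadable from compound 1 to compound 2, so it offers no size to carry over. Compound 1, whose group on that sulfur contains rings, reads > 100000 nM, again a limit. All the evidence is thus (the limit of > 100000 nM in this assay, at which 2 of the 2 values shown sit). No step beyond the scatter is expected in this assay, and the expected change is a number no higher from compound 2 to compound 3 (the limit leaves the size open). For compound 3 the estimate is 100000 nM, with an expected range of 50000 nM to 200000 nM.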

Compound 3, half-maximal inhibitory concentration: > 100000 nM
Compound 3 was reported as a limit (the forecaster's own chance of this, stated with the estimate: 85%); the middle value lies on the limit itself.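

In this assay, compound 3 gives > 100000 nM, which is a limit of the assay. Within the data shown here, compound 1, compound 2 and compound 3 all stand as limits, so no step among them can be read. From the compounds shown here alone, whether the group on the sulfur changes the real value of any of them stays open.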